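The compounds below may be only part of what the source reports. "The series", "measured", "known", "first", "only" and "open" are said of these compounds alone.

In a functional assay on MCF7 cells (Homo sapiens) for cytotoxicity, read by MTT assay, with a stated time of 24 h (a higher number here means a weaker inhibitor, a lower number a stronger inhibitor), compound 1 `CCNc1cc(-c2ccc(NC(=O)Nc3ccc(C(F)(F)F)cc3)cc2C)ccn1` gives 6870 nM and compound 2 `CCNc1cc(-c2ccc(NC(=O)Nc3ccc(OC)cc3)cc2C(F)(F)F)ccn1` gives 5740 nM with the two numbers inside the usual scatter of each other. Compound 3 `CCNc1cc(-c2ccc(NC(=O)Nc3ccc(C(F)(F)F)cc3)cc2C(F)(F)F)ccn1` differs from compound 2 by one exchange (trifluoromethyl in place of methoxy on an aromatic carbon) with trifluoromethyl in place of methoxy on an aromatic carbon. Compound 1 already carries the 4-(trifluoromethyl)phenyl group and reads 6870 nM so in this assay no step beyond the scatter is expected in either direction. The estimated 1.1-fold lower number from compound 2 to compound 3 (0.06 log units; within the scatter) is expected to stay inside that scatter. The expected value for compound 3 is 5000 nM with 2200 nM to 11000 nM as the estimated range.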

Compound 3, half-maximal inhibitory concentration: 2390 nM
Compound 3: the middle estimate sits 2.1-fold (0.32 log units) above what was measured; low and high end bracket the measured number.
By their numbers in this assay, from the lowest: compound 3; then compounds 2 and 1 (each within the scatter of the next).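

In this assay, 4-(trifluoromethyl)phenyl in place of 4-methoxyphenyl, on an aromatic carbon para to a large group, gives a 2.4-fold lower number from compound 2 to compound 3 (0.38 log units; beyond the scatter), so this position does register in the read-out. That group alone does not set the value, since trifluoromethyl in place of methyl elsewhere on the core gives a 2.9-fold lower number from compound 1 to compound 3 (0.46 log units; beyond the scatter). Nothing available here explains either step. Going by these compounds, whether a nitrile, an amine or a carboxylic acid at this position would move the number further remains open. So does whether the methoxy to trifluoromethyl step would hold with methyl at the other position.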